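Swapping the imidazolyl of compound 1 for a cyclopropyl

The source may hold more compounds than are shown below. What is called first, only, known or untested is meant among the compounds shown, and "the series" means these compounds.

Compound 1 `CNc1nc(NC2(C#N)CCCCC2)nc(-n2ccnc2)n1` is the anchor of this small set. Among the measured compounds shown here, in an in vitro assay on Sf21 cells for inhibition of high affinity 3',5'-cyclic-AMP phosphodiesterase 7A (Homo sapiens) (a higher number here means a weaker inhibitor, a lower number a stronger inhibitor), compound 1 gives 1050 nM, the only outright number in the set. Compound 2 `CNc1nc(NC2(C#N)CCCCC2)nc(-n2cnc(C#N)n2)n1` reaches only the limit of > 5000 nM in this assay. Compound 3 `CNc1nc(NC2(C#N)CCCCC2)nc(-n2cnc(C)n2)n1` likewise stops at the limit of > 5000 nM. The step of an at least 4.7-fold higher number from compound 1 to compound 2 (0.67 log units; beyond the scatter) and the step of an at least 4.7-fold higher number from compound 1 to compound 3 (0.67 log units; beyond the scatter) both show that exchanging the imidazolyl group weakens inhibition, though the limit of > 5000 nM in this assay, at which 2 of the 3 values shown sit, leaves their full size open, and it also leaves the step that the two limits leave unreadable from compound 2 to compound 3 unreadable.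

Compound 4 `CNc1nc(NC2(C#N)CCCCC2)nc(C2CC2)n1` has not yet been measured. It differs from compound 1 by cyclopropyl in place of 1H-imidazol-1-yl on an aromatic carbon. For the measured compounds named here, no measured step tests a cyclopropyl, but both exchanges of the imidazolyl so far lost potency, so a weakening in this assay is expected here too, of uncertain size. Compound 4 is therefore estimated at 4000 nM, within a range from 1500 nM to 10000 nM. That estimate is expected to mean a 3.8-fold higher number from compound 1 to compound 4 (0.58 log units; beyond the scatter).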

Compound 4, half-maximal inhibitory concentration: 539 nM
The estimate for compound 4 lay 7.4-fold (0.87 log units) above the measured number; measured number outside the range, below it.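

The loss seen earlier therefore does not come from removing the imidazolyl as such. In this assay, the exchange gives a 1.9-fold lower number from compound 1 to compound 4 (0.29 log units; within the scatter), so cyclopropyl, a small carbon ring with 0 hydrogen-bond acceptors, performs on a par with 1H-imidazol-1-yl at this position. The weak results belong to the two triazolyl groups instead, as the exchanges give an at least 9.2-fold lower number from compound 3 to compound 4 (0.96 log units; beyond the scatter) and an at least 9.2-fold lower number from compound 2 to compound 4 (0.96 log units; beyond the scatter), and how large these two steps really are stays unknown, since compounds 2 and 3 each carry a limit rather than a number: the limit of > 5000 nM in this assay, at which 2 of the 4 values shown sit.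

Going by these compounds, whether a phenyl ring, a larger carbon ring such as cyclohexyl or an amine such as morpholine would also be tolerated here remains open. The compounds shown also cannot tell why the two triazolyl groups fare so much worse than the imidazolyl and the cyclopropyl.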